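The source may report more compounds than this note shows. Statements on the series, on what has been measured and on what is new or still open speak of the compounds shown alone.

In a functional assay on B16-F0 cells (Mus musculus) for inhibition, read by CCK-8 assay, with a stated time of 48 h (on this read-out higher numbers stand for weaker inhibition and lower numbers for stronger inhibition), compound 1 (`COc1cc(-c2ccnc3cc(-c4ccc(F)cc4)nn23)cc(OC)c1OC`) gives 4540 nM, compound 2 (`COc1cc(-c2ccnc3cc(-c4ccccc4)nn23)cc(OC)c1OC`) gives 4730 nM and compound 3 (`COc1cc(-c2ccnc3cc(-c4ccc(C(C)=O)cc4)nn23)cc(OC)c1OC`) gives 3930 nM, so compound 3 stands level with the other two, within the scatter. Compound 4 (`COc1cc(-c2ccnc3cc(-c4ccc(-c5cnn(C)c5)cc4)nn23)cc(OC)c1OC`) carries 1-methyl-1H-pyrazol-4-yl in place of acetyl on an aromatic carbon. Three measured steps involve substituents at this place: a 1.0-fold higher number from compound 1 to compound 2 (0.02 log units; within the scatter), a 1.2-fold lower number from compound 1 to compound 3 (0.06 log units; within the scatter) and a 1.2-fold lower number from compound 2 to compound 3 (0.08 log units; within the scatter). All lie within the scatter, yet none of them brings in a ring, so they guide this change only loosely. With steps as small as a 1.2-fold lower number from compound 2 to compound 3 (0.08 log units; within the scatter), no change beyond the scatter is expected, and the estimated step is a 1.3-fold lower number from compound 3 to compound 4 (0.12 log units; within the scatter). For compound 4 the expected value is 3000 nM, with an estimated range of 700 nM to 7000 nM.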

Compound 4, half-maximal inhibitory concentration: 1240 nM
Compound 4: the middle estimate sits 2.4-fold (0.38 log units) above what was measured, and the stated range covers the measured number.
By their numbers in this assay, from the lowest: compound 4; then compounds 3, 1 and 2 (each within the scatter of the next).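

In this assay, this place first gives a step beyond the scatter when a ring enters: 1-methyl-1H-pyrazol-4-yl gives modest steps against acetyl (a 3.2-fold lower number from compound 3 to compound 4 (0.50 log units; beyond the scatter)), hydrogen (a 3.8-fold lower number from compound 2 to compound 4 (0.58 log units; beyond the scatter)) and fluoro (a 3.7-fold lower number from compound 1 to compound 4 (0.56 log units; beyond the scatter)), while those three groups stand level with one another. No evidence in hand accounts for this difference.

Going by these compounds, whether the lower number goes with the ring as such, its nitrogen atoms or its methyl group stays open; a phenyl ring, a pyrazole without the methyl or a morpholine at this place would help separate these.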